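The source may hold more compounds than are shown below. What is called first, only, known or untested is meant among the compounds shown, and "the series" means these compounds.

Notes on the series, measured in a functional assay on the whole organism with Mus musculus as the target; a higher number here means that more compound is needed for the effect, a lower number that less compound is needed.

Compound 1 `CCCN(c1ccncc1)n1cccc1` gives a limit of the assay, not a number: in this assay compound 1 reads > 20 mg/kg. Compound 2 `CCCCN(c1ccncc1)n1cccc1` likewise gives only a limit: in this assay compound 2 reads > 20 mg/kg. Compound 3 `CN(c1ccncc1)n1cccc1Cl` also gives a limit: in this assay compound 3 reads > 20 mg/kg. All three values sit at the limit of > 20 mg/kg in this assay, at which 3 of the 3 values shown sit, so the step from compound 1 to compound 2 cannot be read: a step that the two limits leave unreadable from compound 1 to compound 2. That step is methyl in place of hydrogen on a saturated chain carbon, three bonds along the chain from a nitrogen on an aromatic ring.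

Compound 4 `CCN(c1ccncc1)n1cccc1Cl` is not yet measured. It differs from compound 3 by methyl in place of hydrogen on a saturated chain carbon bound to a nitrogen on an aromatic ring. For the measured compounds named here, this is the same kind of change as that from compound 1 to compound 2, but not the same: in the one case the change sits on a saturated chain carbon bound to a nitrogen on an aromatic ring, in the other on a saturated chain carbon three bonds along the chain from a nitrogen on an aromatic ring. The difference between the core of compound 3 and the core of compound 1 is not broken down here.

The size of the step from compound 3 to compound 4 is expected to be a step that the limit leaves unreadable from compound 3 to compound 4, which rests on nothing more than the fact that compound 1, compound 2 and compound 3 all sit at the limit of > 20 mg/kg in this assay, at which 3 of the 3 values shown sit; the earlier step of the same kind is unreadable, so no direction can be taken from it. For compound 4 in this assay the expected value is 35 mg/kg, with a range from 12 mg/kg to 150 mg/kg, and the most probable outcome is that the assay again reports only a limit.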

Compound 4, dose for half-maximal effect: > 20 mg/kg
Compound 4: no number, only a limit (the forecaster's own chance of this, stated with the estimate: 80%); the middle value does not contradict the limit.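

In this assay compound 4 gives > 20 mg/kg as a limit of the assay and not a number. For the compounds shown here, the step from compound 3 to compound 4, methyl in place of hydrogen, therefore cannot be read, and no new step arises: the limit of > 20 mg/kg in this assay, at which 4 of the 4 values shown sit. The compounds shown leave open whether any change to the shared core gives a measurable dose, and what size either methyl step has.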